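Oxadiazoline versus hydrazone analogues on the trimethoxyphenyl series

The source may report more compounds than this note shows. Statements on the series, on what has been measured and on what is new or still open speak of the compounds shown alone.

Working notes. Three compounds have been run in a functional assay on PC-3 cells (Homo sapiens) for antiproliferative activity, read by MTT assay, tested at 5 uM; on this read-out higher numbers stand for a stronger effect at the one concentration tested and lower numbers for a weaker effect. Compound 1 `COc1cc(C2=NN(C(C)=O)C(c3ccc(F)c(F)c3)O2)cc(OC)c1OC` gives 46.9% and stands second of the three. Compound 3 `COc1cc(C(=O)N/N=C/c2ccc(Cl)c([N+](=O)[O-])c2)cc(OC)c1OC` gives 42.3%, a number that lies within the scatter of the figure for compound 1, so the two cannot be ordered. Compound 2 `COc1cc(C(=O)N/N=C/c2cccc(C(F)(F)F)c2)cc(OC)c1OC` gives 79.8%, clearly higher than compound 1 and beyond the scatter.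

Compound 4 `COc1cc(C2=NN(C(C)=O)C(c3ccc(Cl)c([N+](=O)[O-])c3)O2)cc(OC)c1OC` has not yet been measured in this assay. It differs from compound 1 in one place: 4-chloro-3-nitrophenyl in place of 3,4-difluorophenyl on a saturated ring carbon. Within the data shown here, no measured pair isolates this change. Among the measured compounds shown here, the only hint comes from compound 3, which carries the same 4-chloro-3-nitrophenyl group on a different core and gives 42.3%, a figure close to that of compound 1.

For compound 4 the step of a number 1.9 percentage points lower from compound 1 to compound 4 (within the scatter) is therefore expected to be small, with no direction beyond the scatter. The estimate for compound 4 in this assay is 45%, with a plausible range from 30% to 62%.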

Compound 4, a percentage reported as inhibition, at one concentration (the size of the read-out at that concentration, not a potency): 61.4%
Compound 4: middle estimate off by 16.4 percentage points, on the low side; low and high end bracket the measured number.
By their numbers in this assay, from the lowest: compounds 3 and 1 (each within the scatter of the next); then compound 4; then compound 2.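

In this assay, among these compounds, 4-chloro-3-nitrophenyl in place of 3,4-difluorophenyl on the saturated ring carbon gives a number 14.5 percentage points higher from compound 1 to compound 4 (beyond the scatter) and provides the first pair that isolates this position. On the shared core, the read-out therefore responds to a change of aryl substituents at this carbon, although the step is modest and rests on one pair. No available measurement bears on the reason for this step.

The chlorine and the nitro group enter together while both fluorines leave, so the compounds shown do not separate their contributions; 4-chlorophenyl and 3-nitrophenyl analogues on the same core would address this. Going by these compounds, it also remains open whether this position tolerates a non-aryl group, such as an aminomethyl or carboxylic acid substituent, and whether the step would persist as a difference in potency.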